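The compounds below may be only part of what the source reports. "The series", "measured", "known", "first", "only" and "open" are said of these compounds alone.

Compound 1 `COC(=O)c1c(-c2ccc(O)cc2)oc2ccccc2c1=O` and compound 2 `COC(=O)c1c(-c2ccc(O)cc2)oc2cc(OC)ccc2c1=O` share one core, while compound 3 `O=C(O)c1c(-c2ccc([N+](=O)[O-])cc2)oc2ccccc2c1=O` and the unmeasured compound 4 `COc1ccc2oc(-c3ccc([N+](=O)[O-])cc3)c(C(=O)O)c(=O)c2c1` share another; the difference between the two cores is not broken down here. In a functional assay on MCF7 cells (Homo sapiens) for cytotoxicity, read by MTT assay, with a stated time of 6 days (a higher number here means that more compound is needed for the effect, a lower number that less compound is needed), compound 1 gives only a limit, > 25 ug/mL. Compound 2 also gives only a limit, > 25 ug/mL. Compound 3 likewise gives only a limit, > 25 ug/mL. The change methoxy in place of hydrogen on an aromatic carbon yields a step that the two limits leave unreadable from compound 1 to compound 2. The same change is now made on the second core: methoxy in place of hydrogen on an aromatic carbon. The step that the limit leaves unreadable from compound 3 to compound 4 is expected to be small, because the limit of > 25 ug/mL in this assay, at which 3 of the 3 values shown sit, holds every reading so far. Compound 4 is therefore estimated at 40 ug/mL, within a range from 15 ug/mL to 120 ug/mL.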

Compound 4, concentration for half-maximal effect: 15.9 ug/mL
Compound 4: middle estimate off by 2.5-fold (0.40 log units), on the high side; the range from low to high includes it.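

In this assay, methoxy in place of hydrogen on an aromatic carbon of the core of compound 3 gives an at least 1.5-fold lower number from compound 3 to compound 4 (0.19 log units; that floor lies within the scatter). The value of compound 3 is a limit and not a number, so only that floor is known, and it does not establish a real change. The same change on the core of compound 1 cannot be read, so the two cores cannot be compared and carrying the change across them remains untested: the limit of > 25 ug/mL in this assay, at which 3 of the 4 values shown sit.

Left open is how an amine or a longer chain in place of the methoxy would read in this assay. Also open, going by these compounds, is whether an amine in place of the nitro group on the core of compound 4 would shift the reading.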